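The source may hold more compounds than are shown below. What is called first, only, known or untested is meant among the compounds shown, and "the series" means these compounds.

Of the compounds shown here, three have so far been tested in a functional assay (aorta) with Rattus norvegicus as the target; on this read-out higher numbers stand for weaker inhibition and lower numbers for stronger inhibition. Compound 1 `CCC(C)(C)/N=C(\NC#N)N[C@@H]1c2cc(C#N)ccc2OC(C)(C)[C@H]1O` gives 29800 nM, compound 2 `CC1(C)Oc2ccc(C#N)cc2[C@@H](NC(=O)Nc2ccncc2)[C@@H]1O` gives 8500 nM, and compound 3 `CC1(C)Oc2ccc(C#N)cc2[C@@H](/N=C(\NC#N)Nc2cccc([N+](=O)[O-])c2)[C@@H]1O` gives 670 nM. Compound 3 thus stands lowest of the three, the strongest inhibitor here, with its gaps to both other compounds beyond the usual scatter. Compound 4 `COc1ccc(N/C(=N/[C@@H]2c3cc(C#N)ccc3OC(C)(C)[C@H]2O)NC#N)cc1` has not yet been measured. It differs from compound 3 in one place: 4-methoxyphenyl in place of 3-nitrophenyl on an amine nitrogen. Going by the values given here, no measured pair shows this kind of exchange, so the size of the step rests on expectation alone. A modest step towards a higher number, that is weaker inhibition, is expected, a 2.7-fold higher number from compound 3 to compound 4 (0.43 log units; beyond the scatter). Compound 4 is therefore estimated at 1800 nM in this assay, with a range from 500 nM to 6500 nM.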

Compound 4, half-maximal inhibitory concentration: 32500 nM
Compound 4: middle estimate off by 18-fold (1.26 log units), on the low side, outside the stated range (above it).
By their numbers in this assay, from the lowest: compound 3; then compound 2; then compounds 1 and 4 (each within the scatter of the next).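

In this assay, exchanging 3-nitrophenyl for 4-methoxyphenyl on the amine nitrogen gives a 49-fold higher number from compound 3 to compound 4 (1.69 log units; beyond the scatter) and marks a large loss of inhibition. Going by these compounds alone, this is the first direct evidence that this single place on the shared core can strongly change the read-out. No measurement shown here explains why the step is so large.

The two groups differ both in what the ring carries and in the numbered place where it carries it, so these two parts of the change cannot be separated. Plain phenyl or a chlorophenyl on the same nitrogen could show whether inhibition stays closer to compound 3 or to compound 4.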